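Methyl additions in one series on tumour cells

The source may report more compounds than this note shows. Statements on the series, on what has been measured and on what is new or still open speak of the compounds shown alone.

Compound 1 `CN1C(=O)CN(C2CCCC2)c2nc(Nc3ccc(N4CCCCC4)cc3)ncc21` is the reference point of the set. In a functional assay on MDA-MB-231 cells (Homo sapiens) for inhibition, read by MTT assay, with a stated time of 48 h (on this read-out lower numbers stand for stronger inhibition and higher numbers for weaker inhibition), compound 1 gives 21200 nM. Compound 2 `CC1CCN(c2ccc(Nc3ncc4c(n3)N(C3CCCC3)CC(=O)N4C)cc2)CC1` carries methyl in place of hydrogen on a saturated ring carbon. In this assay compound 2 reaches only a limit of the assay, > 30000 nM. The step of an at least 1.4-fold higher number from compound 1 to compound 2 (0.15 log units; that floor lies within the scatter) can therefore be sized only from one side. Compound 3 `CCN1C(=O)CN(C2CCCC2)c2nc(Nc3ccc(N4CCCCC4)cc3)ncc21` differs from compound 1 by methyl in place of hydrogen on a saturated chain carbon bound to an amide-type nitrogen in a ring, and this is how the two cores differ. In this assay compound 3 likewise sits at a limit of the assay, > 30000 nM. The step of an at least 1.4-fold higher number from compound 1 to compound 3 (0.15 log units; that floor lies within the scatter) is again bounded only by a floor, as the limit of > 30000 nM in this assay, at which 2 of the 3 values shown sit, shows for two of the three values in hand. Compound 4 `CCN1C(=O)CN(C2CCCC2)c2nc(Nc3ccc(N4CCC(C)CC4)cc3)ncc21` has not yet been measured; relative to compound 3 it adds (methyl in place of hydrogen on a saturated ring carbon), the same change that separates compound 2 from compound 1, with the place described in identical words in both cases. From compound 3 the change is expected to give a step that the limit leaves unreadable from compound 3 to compound 4, resting on the step of an at least 1.4-fold higher number from compound 1 to compound 2 (0.15 log units; that floor lies within the scatter) and on the limit that compound 3 already reaches. For compound 4 the value in this assay is estimated at 45000 nM, most probably reported again only as a limit, within an expected range from 25000 nM to 100000 nM.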

Compound 4, half-maximal inhibitory concentration: > 30000 nM
Compound 4 gave a limit, no number; the forecaster's own chance of this, stated with the estimate: 85%; the middle value lies beyond the limit too.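

In this assay compound 4 gives > 30000 nM, a limit of the assay and not a number. Within the data shown here, no step from compound 2 or compound 3 to compound 4 can be read, because these compounds all sit at the same limit: the limit of > 30000 nM in this assay, at which 3 of the 4 values shown sit. The compounds shown leave open how compound 2, compound 3 and compound 4 compare, and what piperidin-1-yl to 4-methylpiperidin-1-yl does on the core of compound 3.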